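This account rests on a few compounds, and the source may have more. Where it says the series, first, only, none or still open, it means among the compounds named here.

Compound 1 `CCCCCCCCCCCCCCC[C@@H](O)[C@@H](N)C(C)C` gives 7200 nM 
Compound 2 `CCCCCCCCC[C@@H](O)[C@@H](N)C(C)C` gives 17000 nM 

Within the data shown here, in a functional assay on SW1573 cells (Homo sapiens) for antiproliferative activity, read by sulforhodamine B assay, with a stated time of 48 h (on this read-out higher numbers stand for weaker inhibition of growth and lower numbers for stronger inhibition of growth), compound 1 at 7200 nM holds the lower of the two numbers so far. Compound 3 `CCCCCCCCCCCCCCC[C@@H](O)[C@@H](N)[C@@H](C)CC` carries methyl in place of hydrogen on a saturated chain carbon, three bonds along the chain from an amine nitrogen. Among the measured compounds shown here, the only measured step (a 2.4-fold higher number from compound 1 to compound 2 (0.37 log units; beyond the scatter)) was modest, swapped a larger group and lies elsewhere on the chain. No measurement covers this place, so in this assay no step beyond the scatter is expected, and no direction can be favoured (a 1.1-fold lower number from compound 1 to compound 3 (0.04 log units; within the scatter)). Compound 3 is estimated at 6500 nM with an expected range from 3000 nM to 14000 nM for now.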

Compound 3, concentration for 50% growth inhibition: 3400 nM
Compound 3: middle estimate off by 1.9-fold (0.28 log units), on the high side, within the range that was stated.
By their numbers in this assay, from the lowest: compound 3; then compound 1; then compound 2.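

In this assay, methyl in place of hydrogen on a saturated chain carbon, three bonds along the chain from an amine nitrogen, gives a 2.1-fold lower number from compound 1 to compound 3 (0.33 log units; beyond the scatter). Among these compounds, this place, which no earlier step touched, therefore responds to a single added carbon, with isopropyl becoming sec-butyl and growth inhibition becoming stronger. No evidence on why this happens is available.

Going by these compounds, it remains open whether a longer chain or a phenyl ring at this place would go further, or whether a hydroxyl would reverse the change. On these data alone, it is also open whether sec-butyl would give a similar step on the shorter chain of compound 2.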